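A few compounds are considered here, and "the series" means these few. Any claim that something is new, unique, unknown or untested is made for them only; others in the source may bear on it.

Measured compounds:
compound 1 `Nc1scc(-c2cccc(Cl)c2)c1C(=O)c1ccccc1` — 45%
compound 2 `Nc1scc(-c2cccc([N+](=O)[O-])c2)c1C(=O)c1ccccc1` — 47%
compound 3 `COc1cccc(-c2csc(N)c2C(=O)c2ccccc2)c1` — 41%

All three share one core and differ only in the group on the pendant aryl ring. In a functional assay on CHO cells for agonist activity at adenosine receptor A1 (Homo sapiens), read by fluorescence and ERK phosphorylation, with stated times of 30 min and 1.5 h, tested at 3 uM (on this read-out higher numbers stand for a stronger effect at the one concentration tested and lower numbers for a weaker effect), the number for compound 1 falls between the other two, its nearest neighbour being compound 2, with a number 2 percentage points higher from compound 1 to compound 2 (within the scatter), and its furthest compound 3, with a number 4 percentage points lower from compound 1 to compound 3 (within the scatter). The remaining pair shows a number 6 percentage points lower from compound 2 to compound 3 (within the scatter). Every measured step therefore sits within the scatter, and none of them separates the three compounds.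

Compound 4 `Nc1scc(-c2cccc(Cl)c2)c1C(=O)c1ccc(Cl)cc1` differs from compound 1 in another place: chloro in place of hydrogen on an aromatic carbon. Going by the values given here, no measured step touches this ring; the three steps seen concern the other aryl ring only, and each was within the scatter. Nothing in the numbers points to a step in either direction, so for compound 4 the expectation is no change at the digits printed from compound 1 to compound 4 (within the scatter), no change beyond the scatter. Compound 4 is estimated at 45%, between 30% and 60%.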

Compound 4, a percentage reported as activity, at one concentration (the size of the read-out at that concentration, not a potency): 58%
Compound 4: the middle estimate sits 13 percentage points below what was measured; low and high end bracket the measured number.
By their numbers in this assay, from the lowest: compounds 3, 1 and 2 (each within the scatter of the next); then compound 4.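

In this assay the change from phenyl to 4-chlorophenyl gives a number 13 percentage points higher from compound 1 to compound 4 (beyond the scatter) and is the first step among these compounds that lies beyond the scatter. The earlier steps all concerned the other aryl ring and separated nothing, whereas this ring is the one place shown where a single change moves the read-out, with chloro in place of hydrogen raising it modestly at the one concentration tested. Nothing measured here accounts for this step.

Whether the step is particular to chloro stays open, since no other group, such as fluoro, methyl or an amine, is shown at this place on the ring. Going by these compounds, it also remains open whether the same change would raise the read-out with the nitro of compound 2 or the methoxy of compound 3 on the other ring.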